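Trifluoromethyl in place of methyl: expectation for compound 4

The source may report more compounds than this note shows. Statements on the series, on what has been measured and on what is new or still open speak of the compounds shown alone.

Three compounds share one core and differ only in the group on the six-membered aromatic ring of carbon only. Compound 1 `COc1ccc(N/N=C2\CCC(C)n3c2ncc(C(=O)O)c3=O)cc1` gives 0.8 umol/kg in a functional assay on the whole organism for inhibition, with Rattus norvegicus as the target; a lower number here means that less compound is needed, a higher number that more compound is needed for the effect. Compound 2 `CCOc1ccc(N/N=C2\CCC(C)n3c2ncc(C(=O)O)c3=O)cc1` gives 1.6 umol/kg in this assay, and compound 3 `Cc1ccc(N/N=C2\CCC(C)n3c2ncc(C(=O)O)c3=O)cc1` gives 1.3 umol/kg. Compound 3 therefore holds the second highest of the three numbers; its nearest neighbour is compound 2, with a 1.2-fold lower number from compound 2 to compound 3 (0.09 log units; within the scatter), and its furthest is compound 1, with a 1.6-fold higher number from compound 1 to compound 3 (0.21 log units; within the scatter); both gaps lie within the scatter, as does a 2.0-fold higher number from compound 1 to compound 2 (0.30 log units; within the scatter).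

Compound 4 `CC1CC/C(=N\Nc2ccc(C(F)(F)F)cc2)c2ncc(C(=O)O)c(=O)n21` is the next step: trifluoromethyl in place of methyl on an aromatic carbon. For the measured compounds named here, no measured pair involves a trifluoromethyl, so no step bears on the change directly. What the series does show is that three different groups at this place give numbers that all fall within the scatter of one another. The expectation for compound 4 is accordingly a step of a 1.2-fold higher number from compound 3 to compound 4 (0.06 log units; within the scatter), that is, nothing beyond the scatter. Going by the values given here, the range is widened: the entering group has no precedent in the measured set. Compound 4 is estimated at 1.5 umol/kg in this assay, expected to fall between 0.6 umol/kg and 4 umol/kg.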

Compound 4, dose for 50% inhibition: 38.6 umol/kg
For compound 4 the middle estimate is 26-fold (1.41 log units) below the measured one; measured number outside the range, above it.
By their numbers in this assay, from the lowest: compounds 1, 3 and 2 (each within the scatter of the next); then compound 4.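

This position is not indifferent to its group in this assay: methoxy, ethoxy and methyl give numbers within the scatter of one another, but trifluoromethyl stands apart from all three, with a 30-fold higher number from compound 3 to compound 4 (1.47 log units; beyond the scatter) and a 24-fold higher number from compound 2 to compound 4 (1.38 log units; beyond the scatter) and a 48-fold higher number from compound 1 to compound 4 (1.68 log units; beyond the scatter). For the compounds shown here, the flat picture from the earlier compounds therefore holds only for those three groups, and the step from methyl brings in fluorine with no ring, no net charge and no hydrogen-bond donor or acceptor on either side. Nothing available bears on what lies behind this large step.

As far as these compounds go, whether the high number belongs to trifluoromethyl alone or extends to other groups at this place, such as chlorine, a nitrile or a carboxylic acid, remains open, as does whether a longer chain such as propoxy stays with methoxy, ethoxy and methyl. Also open, from the compounds shown here alone, is whether the step from methyl to trifluoromethyl keeps its size when the shared core carries a different group elsewhere, for example an ester in place of the carboxylic acid.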